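The source may report more compounds than this note shows. Statements on the series, on what has been measured and on what is new or still open speak of the compounds shown alone.

Three compounds built on one shared core were tested in a functional assay on QGY7701 cells (Homo sapiens) for cytotoxicity, read by MTT assay, with a stated time of 24 h; on this read-out higher numbers stand for weaker inhibition and lower numbers for stronger inhibition. Compound 1, `C=CC1=C(C(=O)NCC(C)C)C(c2ccc(F)cc2)OC1`, reaches only a limit of this assay, > 100000 nM. Compound 2, `C=CC1=C(C(=O)NCC(C)C)C(c2ccc(Cl)c(Cl)c2)OC1`, likewise ends at a limit, > 100000 nM. Compound 3, `C=CC1=C(C(=O)NC(C)(C)C)C(c2ccc(Cl)c(Cl)c2)OC1`, also gives no more than a limit, > 100000 nM. How the core of compound 1 differs from the core of compound 2 is not broken down here. Compound 3 arises from compound 2 by tert-butyl in place of isobutyl on an amide-type nitrogen, and because every value sits at the limit of > 100000 nM in this assay, at which 3 of the 3 values shown sit, the step that the two limits leave unreadable from compound 2 to compound 3 stays unreadable in size. The unmeasured compound 4, `C=CC1=C(C(=O)NC(C)(C)C)C(c2ccc(F)cc2)OC1`, carries the same change relative to compound 1, namely (tert-butyl in place of isobutyl on an amide-type nitrogen). The expectation for compound 4 rests on compound 1 giving > 100000 nM and on the unreadable a step that the two limits leave unreadable from compound 2 to compound 3, which offers no sign that the exchange of the amide substituent moves the read-out. Compound 4 is therefore expected to give 150000 nM, with a likely span from 50000 nM to 600000 nM, most probably reported once more as a limit. The step that the limit leaves unreadable from compound 1 to compound 4 is accordingly estimated to be small.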

Compound 4, half-maximal inhibitory concentration: > 100000 nM
Compound 4 gave a limit, no number (the forecaster's own chance of this, stated with the estimate: 85%); the middle value is on the limit's open side.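

No new step can be read in this assay: the exchange from compound 1 to compound 4 cannot be sized, and neither can any other step among the four compounds, because all of them end at one limit: the limit of > 100000 nM in this assay, at which 4 of the 4 values shown sit. The compounds shown leave open whether tert-butyl in place of isobutyl on an amide-type nitrogen changes the read-out at all.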